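Fluoro for methoxy on the sulfonyl-bearing ring

The source may report more compounds than this note shows. Statements on the series, on what has been measured and on what is new or still open speak of the compounds shown alone.

Measured in a functional assay on K562 cells (Homo sapiens) for inhibition, read by trypan blue exclusion, with a stated time of 72 h; a higher number here means a weaker inhibitor, a lower number a stronger inhibitor:
Compound 1 `Cn1c(=O)c(S(=O)(=O)c2ccc(F)cc2)cc2cnc(Nc3ccc4[nH]ccc4c3)nc21`: 200 nM
Compound 2 `COc1ccc(S(=O)(=O)c2cc3cnc(Nc4cccc5[nH]ccc45)nc3n(C)c2=O)cc1`: 5000 nM

Compound 2, at 5000 nM, holds the higher number of the two, and compound 1 gives 200 nM, a gap beyond the scatter. Compound 3 `Cn1c(=O)c(S(=O)(=O)c2ccc(F)cc2)cc2cnc(Nc3cccc4[nH]ccc34)nc21` has fluoro in place of methoxy on an aromatic carbon of compound 2, para to a large group (fluoro in place of methoxy on an aromatic carbon). Within the data shown here, no measured pair shows this change alone. Compound 1 also carries 4-fluorophenyl and gives 200 nM, so a moderate drop is expected in this assay. The expected step is a 3.3-fold lower number from compound 2 to compound 3 (0.52 log units; beyond the scatter). For compound 3 the estimate is 1500 nM, with an expected range of 300 nM to 6000 nM.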

Compound 3, half-maximal inhibitory concentration: 750 nM
The estimate for compound 3 lay 2.0-fold (0.30 log units) above the measured number; the range from low to high includes it.
By their numbers in this assay, from the lowest: compound 1; then compound 3; then compound 2.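

In this assay, the change from 4-methoxyphenyl to 4-fluorophenyl can now be read alone, and it gives a 6.7-fold lower number from compound 2 to compound 3 (0.82 log units; beyond the scatter). The indole attachment also counts: 1H-indol-4-yl in place of 1H-indol-5-yl on the nitrogen gives a 3.8-fold higher number from compound 1 to compound 3 (0.57 log units; beyond the scatter). Nothing measured here accounts for either step. On these data alone, it remains open whether the change from methoxy to fluoro would give a similar step on a compound carrying 1H-indol-5-yl. Also open, as far as these compounds go, is how a chloro group or an amine would read in the same place on the ring.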